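Series notes: propyl on the pyrazole nitrogen of compound 3

The source may report more compounds than this note shows. Statements on the series, on what has been measured and on what is new or still open speak of the compounds shown alone.

The series shares an amide-linked core carrying a trifluoromethyl group, with variation at the indazole end. Compound 1 `Cc1ccc(C(=O)Nc2cc(CN3CCN(C)CC3)cc(C(F)(F)F)c2)cc1-c1ccc2cn[nH]c2c1` gives 4.7 nM in an assay on isolated protein for inhibition of Discoidin domain-containing receptor 2 (Homo sapiens), read by ELISA, with a stated time of 60 min; a higher number here means a weaker inhibitor, a lower number a stronger inhibitor. Compound 2 `Cc1ccc(C(=O)Nc2cccc(C(F)(F)F)c2)cc1-c1ccc2c(-c3ccc(N4CCN(C)CC4)cc3)n[nH]c2c1` gives 8.8 nM in this assay. Compound 3 `Cc1ccc(C(=O)Nc2cccc(C(F)(F)F)c2)cc1-c1ccc2c(-c3cn[nH]c3)n[nH]c2c1` gives 55.6 nM in this assay, the highest number of the three; the nearest is compound 2, which sits well beyond the scatter from it, and compound 1 lies further away still.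

Compound 4 `CCCn1cc(-c2n[nH]c3cc(-c4cc(C(=O)Nc5cccc(C(F)(F)F)c5)ccc4C)ccc23)cn1` differs from compound 3 by propyl in place of hydrogen on an aromatic nitrogen. Among the measured compounds shown here, no pair of measured compounds shows this exact change, so the size of the step is not directly supported. Compound 2, which carries a larger substituent at the same end of the core, gives 8.8 nM against 55.6 nM for compound 3, so a step toward a lower number in this assay is expected for compound 4, though with wide uncertainty. The expected step is estimated as a 1.9-fold lower number from compound 3 to compound 4 (0.27 log units; within the scatter). Compound 4 is estimated at 30 nM, expected to fall between 8 nM and 110 nM.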

Compound 4, half-maximal inhibitory concentration: 3.2 nM
The estimate for compound 4 lay 9.4-fold (0.97 log units) above the measured number; the whole stated range lies above it.
By their numbers in this assay, from the lowest: compounds 4, 1 and 2 (each within the scatter of the next, the first and the last beyond it); then compound 3.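

Propyl in place of hydrogen on the aromatic nitrogen of the five-membered ring is a large step in this assay, with a 17-fold lower number from compound 3 to compound 4 (1.24 log units; beyond the scatter). Among the compounds shown here, this is the first reading at this nitrogen, and it shows that the hydrogen there is not needed for a low number in this assay and that a chain on this atom is accepted. Nothing shown accounts for the size of the step.

Going by these compounds, it remains open how the number follows chain size and type, from methyl or ethyl to butyl or a longer chain, and whether a chain ending in an amine or a carboxylic acid behaves like propyl. Also open, on these data alone, is whether the same step appears on a core carrying the side chain of compound 1.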